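A few compounds are considered here, and "the series" means these few. Any claim that something is new, unique, unknown or untested is made for them only; others in the source may bear on it.

Within the data shown here, compound 2 `CCCCCCCCCCCCCC[C@H](OCOC)[C@H](CN1CCCCC1)NC(=O)OC(C)(C)C` is one of two compounds measured so far in a functional assay on NCI-H358 cells (Homo sapiens) for antiproliferative activity, read by sulforhodamine B assay, with a stated time of 48 h, tested at 10 uM (a lower number here means less inhibition, a higher number more inhibition at the concentration tested (going by the name of the read-out)), and on these numbers it stands lowest: compound 2 gives 15.2%. Its nearest neighbour is compound 1 `CCCCCCCCCCCCCC[C@H](OCOC)[C@H](CO)NC(=O)OC(C)(C)C`, which in this assay gives 18.4%; the step of a number 3.2 percentage points lower from compound 1 to compound 2 (within the scatter) lies within the scatter, so the two read as equal.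

The next compound, compound 3 `CCCCCCCCCCCCCC[C@H](OCOC)[C@H](CN1CCN(C)CC1)NC(=O)OC(C)(C)C`, differs from compound 2 in one place: 4-methylpiperazin-1-yl in place of piperidin-1-yl on a saturated chain carbon, two bonds along the chain from an amide-type nitrogen.

Among the measured compounds shown here, only one measured step bears on this change, and only loosely. The step of a number 3.2 percentage points lower from compound 1 to compound 2 (within the scatter) swapped a hydroxy for a piperidin-1-yl at the same place and moved the number by less than the scatter. For the measured compounds named here, the present change keeps a six-membered ring at that place and alters it to 4-methylpiperazin-1-yl; no measured pair shows this exact swap. Going by the values given here, with the one nearby step flat, no step beyond the scatter is expected in this assay in either direction.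

Compound 3 is therefore estimated to give 16% in this assay, within a range from 4% to 30%, which means an expected step of a number 0.8 percentage points higher from compound 2 to compound 3 (within the scatter).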

Compound 3, a percentage reported as inhibition, at one concentration (the size of the read-out at that concentration, not a potency): 18.9%
The estimate for compound 3 lay 2.9 percentage points below the measured number; the measured number falls inside the stated range.
By their numbers in this assay, from the lowest: compounds 2, 1 and 3 (each within the scatter of the next).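

Replacing piperidin-1-yl with 4-methylpiperazin-1-yl, on a saturated chain carbon, two bonds along the chain from an amide-type nitrogen, adds a second ring nitrogen and a methyl group, yet the result in this assay is a number 3.7 percentage points higher from compound 2 to compound 3 (within the scatter) and so shows no real change. Compared directly with the hydroxy group, the same ring gives a number 0.5 percentage points higher from compound 1 to compound 3 (within the scatter), so hydroxy, piperidin-1-yl and 4-methylpiperazin-1-yl all read as equal at this place, and the flat result seen earlier now extends to a second ring. No supporting measurement is available to explain this flatness.

These three compounds leave open whether any group at this place can shift the number beyond the scatter, for example a morpholine ring, a primary amine or a carboxylic acid. They also leave open how the other parts of the shared core contribute, such as whether a shorter chain in place of the long alkyl chain would change the inhibition, and because each number comes from a single concentration, they say nothing about potency.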